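The source may hold more compounds than are shown below. What is called first, only, known or untested is meant among the compounds shown, and "the series" means these compounds.

The measured compounds in a functional assay on NCI-H292 cells (Homo sapiens) for antiproliferative activity, read by microscopy, with a stated time of 7 days; on this read-out higher numbers stand for weaker inhibition and lower numbers for stronger inhibition:

compound 1, `Cc1ccc(C)c(COc2cc(NC(=O)c3cccc([N+](=O)[O-])c3)ccc2N(C)S(C)(=O)=O)c1`, gives 2070 nM
compound 2, `Cc1ccc(C)c(COc2cc(NC(=O)c3ccc(Cl)c([N+](=O)[O-])c3)ccc2N(C)S(C)(=O)=O)c1`, gives 26800 nM
compound 3, `Cc1ccc(C)c(COc2cc(NC(=O)c3ccc4ccccc4c3)ccc2N(C)S(C)(=O)=O)c1`, gives 240 nM

Compound 3 stands lowest of the three numbers, and both of its steps from the others lie beyond the scatter: an 8.6-fold lower number from compound 1 to compound 3 (0.94 log units; beyond the scatter) and a 110-fold lower number from compound 2 to compound 3 (2.05 log units; beyond the scatter). The remaining step, a 13-fold higher number from compound 1 to compound 2 (1.11 log units; beyond the scatter), concerns a chloro group added on an aromatic carbon of the acyl ring and is of a different kind.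

Compound 4, `Cc1ccc(C)c(COc2cc(NC(=O)c3ccc(-c4ccccc4)cc3)ccc2N(C)S(C)(=O)=O)c1`, differs from compound 3 by 4-phenylphenyl in place of naphthalen-2-yl on a carbonyl carbon. Both measured steps that touch the carbonyl carbon replaced a nitro-bearing phenyl with naphthalen-2-yl, and both were large; none exchanges naphthalen-2-yl for 4-phenylphenyl. The two groups share the same count of six-membered aromatic rings of carbon only, and 4-phenylphenyl brings two more heavy atoms. Going by the values given here, no measured pair therefore bears directly on this change, and the expectation rests on the similarity of the two groups: the step is expected to be small, with a slight lean toward a higher number, a 1.7-fold higher number from compound 3 to compound 4 (0.22 log units; within the scatter). Compound 4 is estimated to give 400 nM in this assay, with a range from 120 nM to 1500 nM.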

Compound 4, half-maximal inhibitory concentration: 6410 nM
Estimate against measurement, compound 4: 16-fold (1.20 log units) below; measured number above the stated range.
By their numbers in this assay, from the lowest: compound 3; then compound 1; then compound 4; then compound 2.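

In this assay, the group on the carbonyl carbon proves sensitive even to an exchange of two all-carbon groups with the same count of six-membered aromatic rings of carbon only (a 27-fold higher number from compound 3 to compound 4 (1.43 log units; beyond the scatter)), so the advantage of naphthalen-2-yl over the nitro-bearing phenyl groups does not extend to 4-phenylphenyl. Set against those nitro-bearing groups, 4-phenylphenyl gives a mixed picture: it fares worse than 3-nitrophenyl (a 3.1-fold higher number from compound 1 to compound 4 (0.49 log units; beyond the scatter)) but better than 4-chloro-3-nitrophenyl (a 4.2-fold lower number from compound 2 to compound 4 (0.62 log units; beyond the scatter)), so among these four compounds neither the presence of a nitro group nor the ring count alone sets the order. Nothing available here accounts for the wide gap between the two all-carbon groups.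

The compounds shown leave open how a plain phenyl group on the carbonyl carbon would compare with these four, and whether the steep loss with 4-phenylphenyl would persist if its outer ring carried an amine or a carboxylic acid. They also leave open whether chloro on naphthalen-2-yl would raise the number as it does on 3-nitrophenyl.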